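The source may report more compounds than this note shows. Statements on the series, on what has been measured and on what is new or still open speak of the compounds shown alone.

Notes on the thymidine-carbonate series in a functional assay on MT4 cells (Homo sapiens) for cytotoxicity; on this read-out lower numbers stand for higher toxicity in this test and higher numbers for lower toxicity in this test.

Compound 1 `Cc1cn(C2CC(N=[N+]=[N-])C(COC(=O)OCCCCO)O2)c(=O)[nH]c1=O` in this assay gives only the limit > 50000 nM. Compound 2 `Cc1cn(C2CC(N=[N+]=[N-])C(COC(=O)NCCCC(=O)O)O2)c(=O)[nH]c1=O` likewise reaches only the limit > 50000 nM. Compound 3 `Cc1cn(C2CC(N=[N+]=[N-])C(COC(=O)NCCCN)O2)c(=O)[nH]c1=O` also stops at the limit > 50000 nM. All three therefore sit at the limit of > 50000 nM in this assay, at which 3 of the 3 values shown sit, and the changes at the carbonyl carbon, a step that the two limits leave unreadable from compound 1 to compound 2 and a step that the two limits leave unreadable from compound 1 to compound 3, as well as a step that the two limits leave unreadable from compound 2 to compound 3, cannot be sized.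

Compound 4 `Cc1cn(C2CC(N=[N+]=[N-])C(COC(=O)OCCCO)O2)c(=O)[nH]c1=O` is the next variant, with hydroxy in place of hydroxymethyl on a saturated chain carbon, three bonds along the chain from an oxygen next to a carbonyl group. The change is a shortening of the hydroxyalkyl chain by one carbon, smaller than either of the unreadable steps from compound 1, which both left the limit in place. Compound 4 is expected to remain at the limit as well, the step that the limit leaves unreadable from compound 1 to compound 4 being nominal; the estimate for compound 4 is 80000 nM, between 40000 nM and 200000 nM.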

Compound 4, half-maximal cytotoxic concentration: > 50000 nM
Compound 4: a limit, no number (the forecaster's own chance of this, stated with the estimate: 90%); the middle value lies beyond the limit too.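

For the compounds shown here, compound 4 gives > 50000 nM, a limit and not a number, so no step linking it to compound 1, compound 2 or compound 3 can be read. The compounds shown leave open the actual half-maximal cytotoxic concentration of each, and whether any change at the carbonyl carbon shifts it.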